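The compounds below may be only part of what the source reports. "The series", "measured", "known", "first", "only" and "open" are said of these compounds alone.

Measured so far:
compound 1 `Cn1cncc1C(OCc1ccc(C#N)nc1N1CCN(C(=O)OC(C)(C)C)CC1)c1ccc(C#N)cc1`: 42 nM
compound 2 `Cn1cncc1C(OCc1ccc(C#N)nc1-c1ccc2ccccc2c1)c1ccc(C#N)cc1`: 5500 nM

In an assay on isolated protein (Bos taurus) for inhibition of geranylgeranyl transferase type-1 subunit beta (Homo sapiens) (on this read-out higher numbers stand for weaker inhibition and lower numbers for stronger inhibition), compound 2 gives 5500 nM, the highest of the two numbers at hand. For the measured compounds named here, compound 1 gives 42 nM in this assay, and the gap between the two values lies well beyond the scatter; no single-place step between them is given, so the two numbers simply stand side by side. Compound 3 `Cn1cncc1C(OCc1ccc(C#N)nc1-c1cc(Cl)cc(Cl)c1)c1ccc(C#N)cc1` is the next member, differing from compound 2 in one place: 3,5-dichlorophenyl in place of naphthalen-2-yl on an aromatic carbon. Going by the values given here, no step between measured compounds covers a change of this kind, so there is nothing to copy from. A modest move toward lower numbers is expected, one that may not clear the scatter; the estimated step of a 2.2-fold lower number from compound 2 to compound 3 (0.34 log units; beyond the scatter) is set on that basis. For compound 3 in this assay the estimate is 2500 nM, with a range from 500 nM to 12000 nM.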

Compound 3, half-maximal inhibitory concentration: 1400 nM
Compound 3: middle estimate off by 1.8-fold (0.25 log units), on the high side; measured number inside the range.
By their numbers in this assay, from the lowest: compound 1; then compound 3; then compound 2.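

In this assay, 3,5-dichlorophenyl in place of naphthalen-2-yl on the aromatic carbon next to the ring nitrogen gives a 3.9-fold lower number from compound 2 to compound 3 (0.59 log units; beyond the scatter) and so shows that the read-out at this position responds to a change between two aryl groups, here one six-membered aromatic ring with two chlorines in place of two rings of carbon only. Compound 3 at 1400 nM still stands above compound 1 at 42 nM in this comparison of three groups at the same place. No measurement at hand accounts for the step.

The compounds shown leave open whether the chlorines or the loss of the second ring carries the change. Plain phenyl, a single chlorine or a morpholine at this carbon would bear on that question and on what separates compound 1 from the aryl compounds.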